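This account rests on a few compounds, and the source may have more. Where it says the series, first, only, none or still open, it means among the compounds named here.

Within the data shown here, in a functional assay on DU-145 cells (Homo sapiens) for inhibition, read by trypan blue exclusion, with a stated time of 96 h (a lower number here means a stronger inhibitor of growth, a higher number a weaker inhibitor of growth), compound 1 `Cc1ccc(CS/C(=C/c2c(O)cc(O)cc2O)C(=O)c2ccc(Cl)cc2)cc1` gives 50000 nM, the higher of the two numbers so far, and compound 2 `Cc1ccc(CS/C(=C/c2c[nH]c3ccc(Br)cc23)C(=O)c2ccc(Cl)cc2)cc1` gives 1000 nM. Compound 3 `O=C(/C(=C\c1c(O)cc(O)cc1O)SCc1ccc(Cl)c(Cl)c1)c1ccc(Cl)cc1` has 3,4-dichlorophenyl in place of 4-methylphenyl on a saturated chain carbon bound to a sulfur. Among the measured compounds shown here, the only measured step, a 50-fold lower number from compound 1 to compound 2 (1.70 log units; beyond the scatter), is large but replaces 2,4,6-trihydroxyphenyl, a different place, so it gives no direct guide here. Only a small step in this assay is therefore expected, with a slight lean to a lower number. The estimated move is a 1.7-fold lower number from compound 1 to compound 3 (0.22 log units; within the scatter), possibly within the scatter. Compound 3 is estimated at 30000 nM, with an expected range of 8000 nM to 80000 nM.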

Compound 3, concentration for 50% growth inhibition: 25000 nM
Estimate against measurement, compound 3: 1.2-fold (0.08 log units) above, and the stated range covers the measured number.
By their numbers in this assay, from the lowest: compound 2; then compounds 3 and 1 (each within the scatter of the next).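

In this assay, 3,4-dichlorophenyl in place of 4-methylphenyl on a saturated chain carbon bound to a sulfur gives a 2.0-fold lower number from compound 1 to compound 3 (0.30 log units; within the scatter), so this first reading at the position shows no change beyond the scatter. Both compounds keep 2,4,6-trihydroxyphenyl, so the reading holds only with that group in place. No evidence on hand bears on this result. Going by these compounds, whether the same change behaves alike with the 5-bromo-1H-indol-3-yl group of compound 2 stays open. So does the effect of an amine or a carboxylic acid at this position.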